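Aryl variation on a fused pentacyclic core: cytotoxicity notes

The source may report more compounds than this note shows. Statements on the series, on what has been measured and on what is new or still open speak of the compounds shown alone.

Measured so far:
- compound 1, `O=c1oc2ccccc2c2nc3c(ccc4cc[nH]c43)c(-c3ccc(C(F)(F)F)cc3)c12`: 70700 nM
- compound 2, `O=c1oc2ccccc2c2nc3c(ccc4cc[nH]c43)c(-c3cccc(Br)c3)c12`: 70700 nM

In a functional assay on B16-F10 cells (Mus musculus) for cytotoxicity (on this read-out lower numbers stand for stronger inhibition and higher numbers for weaker inhibition), compound 2 gives 70700 nM, level with compound 1 at the digits shown. Among the compounds with values here, the one measured step, no change at the digits printed from compound 1 to compound 2 (within the scatter), swaps the aryl group on the shared core and moves nothing beyond the scatter. Compound 3, `Cc1ccc(-c2c3ccc4cc[nH]c4c3nc3c2c(=O)oc2ccccc23)cc1`, carries 4-methylphenyl in place of 3-bromophenyl on an aromatic carbon. Within the data shown here, with only that single flat step to go on, the expected change in this assay is none beyond the scatter, so the step from compound 2 to compound 3 is estimated at no change at the digits printed from compound 2 to compound 3 (within the scatter). Compound 3 is therefore expected near 70700 nM, within 30000 nM to 160000 nM.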

Compound 3, half-maximal inhibitory concentration: 70700 nM
Compound 3: middle estimate and measured number agree at the digits printed; the range from low to high includes it.
By their numbers in this assay, from the lowest: compounds 1, 2 and 3 (each within the scatter of the next).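

In this assay, 4-methylphenyl in place of 3-bromophenyl gives no change at the digits printed from compound 2 to compound 3 (within the scatter) on the shared core, and methyl in place of trifluoromethyl gives no change at the digits printed from compound 1 to compound 3 (within the scatter) as the second reading. A methyl-bearing aryl group, with no halogen on it, therefore sits level with both halogen-bearing aryl groups at this position opposite the ring nitrogen. Nothing at hand bears on why these values coincide.

On these data alone, whether an amine or a carboxylic acid on this aryl ring would shift the value remains open. So does whether this position can move the read-out at all.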